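Bromo in Place of Methoxy at the Assay Limit

The compounds below may be only part of what the source reports. "The series", "measured", "known", "first", "only" and "open" are said of these compounds alone.

In an ADME assay on J774 cells (Mus musculus) for cytotoxicity (on this read-out lower numbers stand for an effect already at smaller amounts and higher numbers for an effect only at larger amounts of compound), compound 1 `COC(=O)c1c[nH]c2cc(OCCOc3ccccc3)c(OC)cc2c1=O` gives > 20000 nM as a limit of the assay, not a number. Compound 2 `COC(=O)c1c[nH]c2cc(-c3ccccc3)ccc2c1=O` gives > 20000 nM as a limit too. Thus the limit of > 20000 nM in this assay, at which 2 of the 2 values shown sit, is where compound 1 stands. Going by the values given here, compound 3 `COC(=O)c1c[nH]c2cc(OCCOc3ccccc3)c(Br)cc2c1=O` keeps the core of compound 1 and takes bromo in place of methoxy on an aromatic carbon as its one change, bromo in place of methoxy on an aromatic carbon. Among the compounds with values here, no measured pair shows this swap, so no step beyond the scatter is expected in this assay and the estimate is a number no higher from compound 1 to compound 3 (the limit leaves the size open) for now. For compound 3 the estimate is 20000 nM as the middle, with 9000 nM to 30000 nM as the expected range.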

Compound 3, half-maximal effective concentration: > 20000 nM
Compound 3: no number, only a limit; the forecaster's own chance of this, stated with the estimate: 70%; the middle value lies on the limit itself.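

In this assay compound 3 gives > 20000 nM, a limit of the assay and not a number. No step from compound 1 to compound 3 can be read, since the values share one limit: the limit of > 20000 nM in this assay, at which 3 of the 3 values shown sit.

On these data alone, whether bromo and methoxy differ at all on this read-out stays open.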